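Replacing the aryl group on sulfur in compound 3

A few compounds are considered here, and "the series" means these few. Any claim that something is new, unique, unknown or untested is made for them only; others in the source may bear on it.

Among the compounds with values here, in a functional assay on HCT-116 cells (Homo sapiens) for inhibition, read by CCK-8 assay, with a stated time of 72 h, tested at 8 uM (a lower number here means less inhibition of growth, a higher number more inhibition of growth at the concentration tested), compound 3 `COc1ccc(SCc2ccc(C(=O)Nc3ccccc3N)cc2)cc1` gives 90.1%, the highest of the three numbers so far. Compound 1 `COc1ccc(SCc2ccc(/C=C/C(=O)Nc3ccccc3N)cc2)cc1OC` gives 49.5% and compound 2 `Nc1ccccc1NC(=O)/C=C/c1ccc(CSc2ccc(Cl)cc2)cc1` gives 3.27%, both beyond the scatter below compound 3.

The next compound to be read is compound 4 `Nc1ccccc1NC(=O)c1ccc(CSc2cccc(F)c2)cc1`, with 3-fluorophenyl in place of 4-methoxyphenyl on a sulfur. Within the data shown here, one measured step bears on this change: a number 46.2 percentage points lower from compound 1 to compound 2 (beyond the scatter), a large one, with 4-chlorophenyl in place of 3,4-dimethoxyphenyl on a sulfur. Both changes exchange a methoxy-bearing phenyl for a halogen-bearing phenyl. The transfer is uncertain, however. Among the measured compounds shown here, that step sits on the core of compound 1, which differs from the core of compound 3, and no step has yet been measured on the core of compound 3.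

A fall in this assay beyond the scatter is therefore expected, with its size poorly fixed by a single precedent. The estimated step is a number 38.1 percentage points lower from compound 3 to compound 4 (beyond the scatter). For compound 4 the estimate is 52%, with an expected range from 15% to 85%.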

Compound 4, percent growth inhibition at one concentration: 81.4%
The estimate for compound 4 lay 29.4 percentage points below the measured number, within the range that was stated.
By their numbers in this assay, from the lowest: compound 2; then compound 1; then compounds 4 and 3 (each within the scatter of the next).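

On the shared core, 3-fluorophenyl in place of 4-methoxyphenyl on a sulfur gives a number 8.7 percentage points lower from compound 3 to compound 4 (within the scatter) in this assay, so on this core growth inhibition at the concentration tested is kept with a halogen-bearing phenyl in place of a methoxy-bearing phenyl. Within the data shown here, this is the first step measured on this core, and it does not repeat the large step seen on the core of compound 1, a number 46.2 percentage points lower from compound 1 to compound 2 (beyond the scatter), so a halogen-bearing phenyl on the sulfur does not bring a large loss in every setting, though the two steps differ in their aryl groups as well as in their cores. Nothing at hand accounts for the difference between these two steps.

Still open, from the compounds shown here alone, is how 4-chlorophenyl and 3,4-dimethoxyphenyl on the sulfur read on the core of compound 3, which would separate the effect of the aryl group from that of the core. Also open, going by these compounds, is how far the position stretches beyond substituted phenyl groups, for instance to a phenyl bearing a carboxylic acid or an amine, or to a longer chain on the sulfur.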